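Shortening One Side of a Two-Sided Compound

A few compounds are considered here, and "the series" means these few. Any claim that something is new, unique, unknown or untested is made for them only; others in the source may bear on it.

In an assay on SW1353 cells (Homo sapiens) for inhibition, read by a luciferase reporter, with stated times of 30 min and 8 h (on this read-out higher numbers stand for weaker inhibition and lower numbers for stronger inhibition), compound 1 `O=c1sc2ccccc2n1CCCCCN1CCN(CCCCCn2c(=O)sc3ccccc32)CC1` gives 430 nM and compound 2 `O=c1sc2ccccc2n1CCCCCCN1CCN(CCCCCCn2c(=O)sc3ccccc32)CC1` gives 410 nM. Within the data shown here, these two values lie within the usual scatter of each other, so compound 1 stands level with the only other number available.

Compound 3 `O=c1sc2ccccc2n1CCCCCN1CCN(CCCn2c(=O)sc3ccccc32)CC1` has not yet been measured. It keeps the core of compound 1 but changes one side: a group of 10 heavy atoms (7 carbon, 1 nitrogen, 1 oxygen, 1 sulfur; one five-membered aromatic ring with 2 hetero atoms, one six-membered aromatic ring of carbon only) in place of a group of 12 heavy atoms (9 carbon, 1 nitrogen, 1 oxygen, 1 sulfur; one five-membered aromatic ring with 2 hetero atoms, one six-membered aromatic ring of carbon only), on a saturated chain carbon, three bonds along the chain from an amine nitrogen in a ring. The change sits on a saturated chain carbon, three bonds along the chain from an amine nitrogen in a ring.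

Among the measured compounds shown here, no measured pair shows a change to one side alone, so the direction is uncertain. A small move towards weaker inhibition seems the likeliest outcome, possibly no larger than the scatter. The expected size is a 1.3-fold higher number from compound 1 to compound 3 (0.11 log units; within the scatter). Compound 3 is estimated at 550 nM, with an expected range from 220 nM to 1300 nM.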

Compound 3, half-maximal inhibitory concentration: 1460 nM
Compound 3: the middle estimate sits 2.7-fold (0.42 log units) below what was measured, outside the stated range (above it).
By their numbers in this assay, from the lowest: compounds 2 and 1 (each within the scatter of the next); then compound 3.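

In this assay, placing the group of 10 heavy atoms where the group of 12 heavy atoms stood, on one side only, gives a 3.4-fold higher number from compound 1 to compound 3 (0.53 log units; beyond the scatter). Among these compounds, this is the first measured pair to change one side alone, and it shows that this side responds to the change by more than the scatter. The two groups have the same rings, hydrogen-bond donors and acceptors and net charge, and differ only in their carbon count, yet nothing available explains why inhibition weakens here.

Going by these compounds, whether the same shortening on the other side would weaken inhibition further remains open, as does whether a longer chain on this side would strengthen it. It is also unknown how a group ending in an amine or a carboxylic acid would fare in this place.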